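The compounds below may be only part of what the source reports. "The series", "measured", "known", "first", "only" and "open" are said of these compounds alone.

Measured compounds:
Compound 1 `CCc1nc2c(-c3ccc(C(F)(F)F)cc3Cl)ccnc2n1C(CC)CCOC` gives 0.7 nM in an assay for binding affinity to Corticotropin releasing factor receptor (Rattus norvegicus); on this read-out lower numbers stand for stronger inhibition and higher numbers for weaker inhibition.
Compound 2 `CCCC(C)n1c(CC)nc2c(-c3ccc(C(C)OC)cc3Cl)ccnc21` gives 3.5 nM in this assay.
Compound 3 `CCCC(C)n1c(CC)nc2c(-c3ccc(C(F)(F)F)cc3Cl)ccnc21` gives 1.1 nM in this assay.

Compound 3 holds the second highest of the three numbers. Its nearest neighbour is compound 1, reached by a 1.6-fold higher number from compound 1 to compound 3 (0.20 log units; within the scatter), a step inside the scatter. Its furthest neighbour is compound 2, from which it differs by a 3.2-fold lower number from compound 2 to compound 3 (0.50 log units; beyond the scatter) on the aromatic carbon.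

Compound 4 `CCc1nc2c(-c3ccc(C(F)(F)F)cc3Cl)ccnc2n1C(CC)COC` is not yet measured. It differs from compound 3 in one place: 1-(methoxymethyl)propyl in place of 1-methylbutyl on an aromatic nitrogen. Among the compounds with values here, the only measured step that touches the same position is the one from compound 1 to compound 3, where a methoxy-bearing chain on the same aromatic nitrogen gave a number within the scatter of the plain 1-methylbutyl. Compound 4 carries a shorter methoxy-bearing chain at that nitrogen, so no step beyond the scatter is expected in this assay, with a lean, if any, toward a slightly lower number as seen for compound 1 at 0.7 nM. For compound 4 the expected value is 0.8 nM, ranging from 0.3 nM to 2.5 nM. This estimate means a 1.4-fold lower number from compound 3 to compound 4 (0.14 log units; within the scatter), a change expected to stay within the scatter.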

Compound 4, inhibition constant: 4.7 nM
For compound 4 the middle estimate is 5.9-fold (0.77 log units) below the measured one, outside the stated range (above it).
By their numbers in this assay, from the lowest: compounds 1 and 3 (each within the scatter of the next); then compounds 2 and 4 (each within the scatter of the next).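

At the aromatic nitrogen, a methoxy-bearing chain is not simply interchangeable with 1-methylbutyl in this assay, as 1-(methoxymethyl)propyl gives a 4.3-fold higher number from compound 3 to compound 4 (0.63 log units; beyond the scatter) and so moves beyond the scatter, which the earlier pair at this position did not do. Chain length matters as well, since shortening the methoxy-bearing chain of compound 1 gives a 6.7-fold higher number from compound 1 to compound 4 (0.83 log units; beyond the scatter) even though the ether oxygen is retained, so the presence of a methoxy group alone does not set the number here. The material shown offers no measurement that accounts for this difference.

On these data alone, it remains open whether a longer chain, such as 1-(3-methoxypropyl)propyl, would stay close to compound 1 or move away from it. Equally open, as far as these compounds go, is how a hydroxyl or an amine in place of the methoxy would behave at this nitrogen.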